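Aryl variation at the core and Huh-7 cytotoxicity

This account rests on a few compounds, and the source may have more. Where it says the series, first, only, none or still open, it means among the compounds named here.

Measured so far:
compound 1, `CN(C)CCCCOC(=O)Nc1ccc(Cn2nc(-c3ccncc3)c3ccccc3c2=O)cc1`: 62700 nM
compound 2, `COc1cccc(-c2nn(Cc3ccc(NC(=O)OCCCCN(C)C)cc3)c(=O)c3ccccc23)c1`: 17600 nM

Among the compounds with values here, in an ADME assay on Huh-7 cells (Homo sapiens) for cytotoxicity, read by MTT assay, with a stated time of 48 h (on this read-out higher numbers stand for lower toxicity in this test and lower numbers for higher toxicity in this test), compound 2 gives the lower of the two numbers; its nearest neighbour is compound 1, and the single measured step at this position is a 3.6-fold lower number from compound 1 to compound 2 (0.55 log units; beyond the scatter), a modest one. Compound 3, `CN(C)CCCCOC(=O)Nc1ccc(Cn2nc(-c3ccccc3C(F)(F)F)c3ccccc3c2=O)cc1`, differs from compound 2 by 2-(trifluoromethyl)phenyl in place of 3-methoxyphenyl on an aromatic carbon. Within the data shown here, no measured step covers this exchange, so only the modest size of the one step at this position guides the expectation. A step of a 1.1-fold higher number from compound 2 to compound 3 (0.06 log units; within the scatter) is expected, probably not far beyond the scatter. Compound 3 is therefore estimated at 20000 nM, between 8000 nM and 60000 nM.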

Compound 3, half-maximal cytotoxic concentration: 35700 nM
The estimate for compound 3 lay 1.8-fold (0.25 log units) below the measured number; the measured number falls inside the stated range.
By their numbers in this assay, from the lowest: compound 2; then compounds 3 and 1 (each within the scatter of the next).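

In this assay, a 2.0-fold higher number from compound 2 to compound 3 (0.31 log units; beyond the scatter), so exchanging the 3-methoxyphenyl for 2-(trifluoromethyl)phenyl moves the number modestly upward. Meanwhile, a 1.8-fold lower number from compound 1 to compound 3 (0.24 log units; within the scatter), which leaves 2-(trifluoromethyl)phenyl and pyridin-4-yl not separated at this position, and among these three aryl groups only the 3-methoxyphenyl of compound 2 stands apart. Nothing available accounts for these differences.

The names 3-methoxyphenyl and 2-(trifluoromethyl)phenyl differ in both substituent and its place on the ring, and these two changes cannot be told apart. On these data alone, how an unsubstituted phenyl or an aminophenyl would read at this position remains open.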